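This account rests on a few compounds, and the source may have more. Where it says the series, first, only, none or still open, it means among the compounds named here.

Measured compounds in a functional assay on HepG2 cells (Homo sapiens) for inhibition, read by sulforhodamine B assay, with a stated time of 48 h; on this read-out higher numbers stand for weaker inhibition of growth and lower numbers for stronger inhibition of growth:
compound 1, `COC(=O)c1sc2cccnc2c1Nc1ccc(OC)cc1N`: 1000 nM
compound 2, `COc1ccccc1Oc1ccnc2ccsc12`: 62700 nM
compound 3, `COc1ccc(Oc2ccnc3ccsc23)cc1`: 53200 nM

Compound 2 gives the highest number of the three in this assay. Compound 3 sits within the usual scatter of it, so the two cannot be told apart on these numbers; compound 1, by contrast, lies well beyond the scatter and is a far stronger inhibitor of growth. Compound 4, `Fc1ccccc1Oc1ccnc2ccsc12`, has not yet been measured. It differs from compound 2 in one place: fluoro in place of methoxy on an aromatic carbon. For the measured compounds named here, no measured pair shows this exchange, so its effect is unknown here. With nothing to point either way, a step within the scatter is expected, a 1.0-fold lower number from compound 2 to compound 4 (0.02 log units; within the scatter). Compound 4 is therefore estimated at 60000 nM, in a range from 20000 nM to 150000 nM.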

Compound 4, concentration for 50% growth inhibition: 16400 nM
The estimate for compound 4 lay 3.7-fold (0.56 log units) above the measured number, outside the stated range (below it).
By their numbers in this assay, from the lowest: compound 1; then compound 4; then compounds 3 and 2 (each within the scatter of the next).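

In this assay, this aromatic carbon, ortho to a large group, proves sensitive to what it carries: fluoro in place of methoxy gives a 3.8-fold lower number from compound 2 to compound 4 (0.58 log units; beyond the scatter), a modest step towards stronger inhibition of growth. For the compounds shown here, this is the first exchange at this position that can be read, as no earlier pair differed in one place. Nothing available accounts for this step.

Going by these compounds, whether chloro, methyl or an amine at this carbon would match fluoro remains open. So does whether fluoro would give a similar step at the place methoxy occupies in compound 3.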